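This account rests on a few compounds, and the source may have more. Where it says the series, first, only, none or still open, it means among the compounds named here.

Two compounds of the series carry numbers in a functional assay on SNB-19 cells (Homo sapiens) for antiproliferative activity, read by sulforhodamine B assay, with a stated time of 48 h; a higher number here means a weaker inhibitor of growth, a lower number a stronger inhibitor of growth. Compound 1 `Cc1nc(SCC(=O)Nc2nc(-c3ccc(Cl)cc3)cs2)n(Nc2ccccc2)c1C` gives 9410 nM in this assay. Compound 2 `Cc1ccc(Nn2c(SCC(=O)Nc3nc(-c4ccccc4)cs3)nc(C)c2C)cc1` gives 7490 nM in this assay. Compound 1 has the highest of the two numbers, yet its nearest neighbour is compound 2, and the gap between them lies within the scatter, so no order between the two can be read from what is in hand.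

Compound 3 `COc1ccc(Nn2c(SCC(=O)Nc3nc(-c4ccc(Cl)cc4)cs3)nc(C)c2C)cc1` has not been measured in this assay. It differs from compound 1 in one place: methoxy in place of hydrogen on an aromatic carbon. The methoxy enters on an aromatic carbon of a six-membered aromatic ring of carbon only, para to a large group, so that the anilino of compound 1 reads as (4-methoxyphenyl)amino in compound 3.

For the measured compounds named here, no pair of measured compounds shows this change. Going by the values given here, the single comparison available, compound 1 against compound 2, concerns other parts of the molecule and falls within the scatter. On this basis no step beyond the scatter is expected for the change. The expected step is a 1.1-fold lower number from compound 1 to compound 3 (0.04 log units; within the scatter). Compound 3 is estimated at 8500 nM in this assay, within the range 3000 nM to 25000 nM.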

Compound 3, concentration for 50% growth inhibition: 6200 nM
Estimate against measurement, compound 3: 1.4-fold (0.14 log units) above; low and high end bracket the measured number.
By their numbers in this assay, from the lowest: compounds 3, 2 and 1 (each within the scatter of the next).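

Compound 1 and compound 3 are the only pair shown that differs in one place, and the change gives a 1.5-fold lower number from compound 1 to compound 3 (0.18 log units; within the scatter) in this assay, so this methoxy now has a direct reading. On this background, the anilino of compound 1 and the (4-methoxyphenyl)amino of compound 3 cannot be told apart in this read-out: a methoxy on this aromatic carbon, para to a large group, leaves the number within the scatter of the hydrogen compound. Nothing at hand explains this outcome or bears on the result.

On these data alone, this is a single group at a single place on a single background, so it remains open whether an amine such as dimethylamino, a carboxylic acid or a longer chain such as butoxy at this carbon would give a step beyond the scatter. As far as these compounds go, it is also open whether the methoxy change would read the same way on other members, such as compound 2, where the thiazole-bound aryl group and the anilino substituent differ.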